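Dropping One Chloro from a Dichloro Benzylidene Ketone

A few compounds are considered here, and "the series" means these few. Any claim that something is new, unique, unknown or untested is made for them only; others in the source may bear on it.

Of the compounds shown here, three have been measured in a functional assay on P388 cells (Mus musculus) for inhibition; on this read-out higher numbers stand for weaker inhibition and lower numbers for stronger inhibition. Compound 1 `O=C1/C(=C/c2ccccc2Cl)Cc2ccccc21` gives 26500 nM in this assay, compound 3 `O=C1/C(=C/c2ccccc2Br)CCc2ccccc21` gives 19700 nM, and compound 2 `O=C1/C(=C/c2ccc(Cl)cc2Cl)CCCc2ccccc21` gives 14000 nM. Compound 2 thus holds the lowest of the three numbers, yet its gaps to compound 3 and to compound 1 both lie within the usual scatter, so no order among them can be claimed. Compound 4 `O=C1/C(=C/c2ccccc2Cl)CCCc2ccccc21` differs from compound 2 by hydrogen in place of chloro on an aromatic carbon. Going by the values given here, no step between measured compounds mirrors this change. Since compound 1, carrying a single chloro on its own core, shows 26500 nM, only a small step toward a higher number is expected, likely within the scatter. Compound 4 is therefore estimated at 20000 nM, ranging from 8000 nM to 50000 nM, an expected change of a 1.4-fold higher number from compound 2 to compound 4 (0.15 log units; within the scatter).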

Compound 4, half-maximal inhibitory concentration: 12700 nM
Compound 4: middle estimate off by 1.6-fold (0.20 log units), on the high side; low and high end bracket the measured number.
By their numbers in this assay, from the lowest: compounds 4, 2, 3 and 1 (each within the scatter of the next, the first and the last beyond it).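

In this assay, hydrogen in place of chloro on this aromatic carbon, meta to a chloro group and para to a large group, gives a 1.1-fold lower number from compound 2 to compound 4 (0.04 log units; within the scatter). Going by these compounds alone, this is the first direct reading of the position: with the other chloro and the core shared, the read-out cannot separate the two compounds. No measurement at hand explains this outcome. Still open, from the compounds shown here alone, is whether an amine, a carboxylic acid or a longer chain at this position would read alike, and whether the same exchange would read the same on the core of compound 1.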